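The source may hold more compounds than are shown below. What is called first, only, known or untested is meant among the compounds shown, and "the series" means these compounds.

Of the compounds shown here, three have been measured in a physicochemical assay for lipophilicity, read by LC-MS, in phosphate buffer, measured as octanol-water partition, with a stated time of 30 min, at pH 7.4, tested at 200 mM (a lower number here means a more polar compound, a higher number a more lipophilic compound), so far. Compound 1 `Cc1ccc(Oc2ccc3nc(COc4cccc(C(=O)O)c4)n(C)c3n2)cc1F` gives 2.1. Within the data shown here, compound 2 `Cn1c(COc2cccc(C(=O)O)c2)nc2ccc(Oc3ccc4c(c3)OCC4)nc21` gives 1.4, and the only single-point step among the measured compounds is a number 0.70 log units lower from compound 1 to compound 2 (beyond the scatter), a swap of the group on the aromatic ether oxygen. Compound 3 `Cn1c(COc2cccc(C(=O)O)c2)nc2ccc(Oc3ccc(F)cn3)cc21` gives 0.6, the lowest of the three numbers; compound 2 is the nearest to it and compound 1 the furthest, both beyond the scatter.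

Compound 4 `Cc1cc(Cl)cnc1Oc1ccc2nc(COc3cccc(C(=O)O)c3)n(C)c2c1` is the next step from compound 3. The change is 5-chloro-3-methylpyridin-2-yl in place of 5-fluoropyridin-2-yl on an oxygen on an aromatic ring. This sits at the same oxygen as the change from compound 1 to compound 2, where a different aromatic group produced a step beyond the scatter, so a change of the group at this oxygen can move the number noticeably. Among the measured compounds shown here, no measured pair shows a fluorine replaced by a chlorine together with an added methyl, so the size is uncertain. The entering group is larger than the leaving one, and an upward move in this assay is expected, with the step of a number 0.90 log units higher from compound 3 to compound 4 (beyond the scatter). Compound 4 is therefore estimated at 1.5, most likely between 1 and 2.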

Compound 4, distribution coefficient: 1.8
Estimate against measurement, compound 4: 0.30 log units below; the measured number falls inside the stated range.
By their numbers in this assay, from the lowest: compound 3; then compound 2; then compounds 4 and 1 (each within the scatter of the next).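

In this assay, among these compounds, replacing 5-fluoropyridin-2-yl with 5-chloro-3-methylpyridin-2-yl on the aromatic ether oxygen gives a number 1.20 log units higher from compound 3 to compound 4 (beyond the scatter) and marks the first rise seen at this oxygen, whereas the only earlier step there, a number 0.70 log units lower from compound 1 to compound 2 (beyond the scatter), was a fall on a different core. The number can therefore move in either direction when the group at this oxygen changes, and the new step is a large one. It also arises with the pyridine ring kept in place and the counts of hydrogen-bond donors and acceptors in the group unchanged, but nothing measured here accounts for its size.

The step combines two edits, chlorine in place of fluorine and an added methyl, so the compounds shown cannot divide it between them; a pyridine carrying only the chlorine or only the methyl would separate the two. Also open is how this assay would read with an amine or a nitrile in place of the chlorine on this ring, since neither group appears among these compounds.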